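A Further Methyl on the Acid Chain

The source may hold more compounds than are shown below. What is called first, only, known or untested is meant among the compounds shown, and "the series" means these compounds.

Compound 1 `CN(Cc1ccccc1OCCCCCC(=O)O)C(=O)c1ccc(-c2ccco2)cc1` and compound 2 `CC(CCCCOc1ccccc1CN(C)C(=O)c1ccc(-c2ccco2)cc1)C(=O)O` share one core and have both been tested in an ADME assay on the whole organism (strain CD-1) for metabolic stability, with Mus musculus as the target, at a dose of 3 mg/kg by the intravenous route; a lower number here means that the compound disappears faster, a higher number that the compound lasts longer. In this assay compound 1 gives 1.7 h and compound 2 gives 2.8 h, so the two stand within the scatter of each other. Compound 3 `CN(Cc1ccccc1OCCCCC(C)(C)C(=O)O)C(=O)c1ccc(-c2ccco2)cc1` has not yet been measured. Its difference from compound 2 is methyl in place of hydrogen on a saturated chain carbon bound to a carbonyl carbon and two saturated chain carbons. Within the data shown here, one measured step bears on this, the methyl-for-hydrogen change a 1.6-fold higher number from compound 1 to compound 2 (0.22 log units; within the scatter). Among the measured compounds shown here, with only that small step as a guide, no change beyond the scatter is expected. The estimated step is a 1.2-fold higher number from compound 2 to compound 3 (0.07 log units; within the scatter). For compound 3 the expected half-life is 3.3 h, within an estimated range of 1.6 h to 6.5 h.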

Compound 3, half-life: 4.6 h
For compound 3 the middle estimate is 1.4-fold (0.14 log units) below the measured one, and the stated range covers the measured number.
By their numbers in this assay, from the lowest: compounds 1, 2 and 3 (each within the scatter of the next, the first and the last beyond it).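

In this assay, the second methyl on the saturated chain carbon bound to a carbonyl carbon gives a 1.6-fold higher number from compound 2 to compound 3 (0.22 log units; within the scatter), so this single change, like the one before it, does not pass the scatter. Read as one replacement, 1-carboxy-1-methylethyl in place of carboxymethyl gives a 2.7-fold higher number from compound 1 to compound 3 (0.43 log units; beyond the scatter), and this is the only step among the three compounds to pass beyond the scatter, a modest separation that appears only when both methyls are taken together. Nothing at hand explains the difference in half-life among these compounds.

The compounds shown leave open whether ethyl in place of these methyls would go with a longer or a shorter half-life. They also leave open how a primary amide or a tetrazole in place of the carboxylic acid would read in this assay and whether a shorter chain would keep the separation.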